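Methylcarbamoyl for methyl: cytotoxicity notes on the series

The source may report more compounds than this note shows. Statements on the series, on what has been measured and on what is new or still open speak of the compounds shown alone.

Values measured in an ADME assay on HEK293 cells (Homo sapiens) for cytotoxicity, with a stated time of 6 h (on this read-out higher numbers stand for lower toxicity in this test and lower numbers for higher toxicity in this test), follow
Compound 1 `CCCCCNc1nc(N)nc2ccccc12` gives > 25000 nM as a limit
Compound 2 `CCCCNc1nc(N)nc2cc(F)c(F)cc12` gives > 18000 nM as a limit
Compound 3 `CCCCNc1nc(N)nc2cccc(C)c12` gives > 25000 nM as a limit

Every entry here is a limit of the assay and not a number. Compound 3 stands at the limit of > 25000 nM in this assay, at which 2 of the 3 values shown sit, and has no number of its own. The next compound to be read is compound 4 `CCCCNc1nc(N)nc2cccc(C(=O)NC)c12` and it has no value yet. It carries methylcarbamoyl in place of methyl on an aromatic carbon of a six-membered aromatic ring of carbon only, and the counted difference from compound 3 is methylcarbamoyl in place of methyl on an aromatic carbon in full. Going by the values given here, no two measured compounds differ in one place only, so no measured step gives a size for this change. In this assay no step beyond the usual scatter is expected, and no direction is favoured. The expected change is a number no higher from compound 3 to compound 4 (the limit leaves the size open) on this estimate. This expectation rests on compound 3 with > 25000 nM as a limit. A report of compound 4 as a limit again is the likeliest outcome. For compound 4 the estimated half-maximal cytotoxic concentration is 25000 nM with an expected range from 12000 nM to 50000 nM in this test.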

Compound 4, half-maximal cytotoxic concentration: > 25000 nM
Compound 4 was reported as a limit; the forecaster's own chance of this, stated with the estimate: 85%; the middle value sits exactly at the limit.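

Compound 3 and compound 4 both stand as limits and not as numbers in this assay, and the step between them cannot be read. The compounds shown leave open whether methylcarbamoyl in place of methyl on an aromatic carbon changes the half-maximal cytotoxic concentration at all, and by how much.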